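Fluoro in place of hydrogen on the phenyl of compound 1

A few compounds are considered here, and "the series" means these few. Any claim that something is new, unique, unknown or untested is made for them only; others in the source may bear on it.

Compound 1 `Cn1c(=O)c(=O)n(C2CCCC2)c2nc(N/N=C/c3ccccc3)ncc21` carries an unsubstituted phenyl. In a functional assay on HCT-116 cells (Homo sapiens) for antiproliferative activity, read by MTT assay (on this read-out higher numbers stand for weaker inhibition and lower numbers for stronger inhibition), compound 1 gives > 100000 nM, which is a limit of the assay and not a number (the limit of > 100000 nM in this assay, at which 1 of the 3 values shown sits). Compound 2 `COc1cccc(/C=N/Nc2ncc3c(n2)n(C2CCCC2)c(=O)c(=O)n3C)c1` gives 45800 nM in this assay, and compound 3 `Cn1c(=O)c(=O)n(C2CCCC2)c2nc(N/N=C/c3cccc([N+](=O)[O-])c3)ncc21` gives 15200 nM. The steps from the parent read an at least 2.1-fold lower number from compound 1 to compound 2 (0.33 log units; beyond the scatter) and an at least 6.5-fold lower number from compound 1 to compound 3 (0.81 log units; beyond the scatter); between the two substituted analogues the step is a 3.0-fold lower number from compound 2 to compound 3 (0.48 log units; beyond the scatter).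

Compound 4 `Cn1c(=O)c(=O)n(C2CCCC2)c2nc(N/N=C/c3ccccc3F)ncc21` differs from compound 1 by fluoro in place of hydrogen on an aromatic carbon. The two measured steps from compound 1 both add a group to the phenyl and both lower the number, at least modestly; the fluoro enters at a different place on the ring, so a downward step of similar or smaller size is expected, with the parent's limit leaving its true size open. Compound 4 is expected at 70000 nM (range 25000 nM to 200000 nM), which means an at least 1.4-fold lower number from compound 1 to compound 4 (0.15 log units; that floor lies within the scatter). With compound 1 at the limit of > 100000 nM in this assay, at which 1 of the 3 values shown sits, the reading for compound 4 may itself come back only as a limit.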

Compound 4, half-maximal inhibitory concentration: 20700 nM
Beside the measured number, compound 4's estimate is 3.4-fold (0.53 log units) above it; the measured number lies below the stated range.
By their numbers in this assay, from the lowest: compounds 3 and 4 (each within the scatter of the next); then compound 2. At a limit, above all of these: compound 1.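

A single fluoro on an aromatic carbon, ortho to a large group, is enough to shift the read-out in this assay, giving an at least 4.8-fold lower number from compound 1 to compound 4 (0.68 log units; beyond the scatter). The 2-fluorophenyl does not separate from the 3-nitrophenyl, with a 1.4-fold higher number from compound 3 to compound 4 (0.13 log units; within the scatter), and it stands clear of the 3-methoxyphenyl, with a 2.2-fold lower number from compound 2 to compound 4 (0.34 log units; beyond the scatter), so a nitro is not needed to reach this level on the phenyl. The first of these steps remains only a floor, as the value of compound 1 is a limit and not a number: the limit of > 100000 nM in this assay, at which 1 of the 4 values shown sits.

From the compounds shown here alone, whether the level follows the group or its place on the ring stays open, as the 2-fluorophenyl, 3-nitrophenyl and 3-methoxyphenyl differ in both at once. Also open, going by these compounds, is how an amine or a carboxylic acid on the phenyl would read in this assay.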